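Swapping a Hydroxyalkyl Ester for a Fluorobenzyl Ester

A few compounds are considered here, and "the series" means these few. Any claim that something is new, unique, unknown or untested is made for them only; others in the source may bear on it.

Compound 1 `CCn1c(C(=O)NCCN(C)C)ccc1C(CC)(CC)c1ccc(OCC(=O)C(C)(C)C)c(C)c1`: 77 nM
Compound 2 `CCn1c(C(=O)NCC(OC)OC)ccc1C(CC)(CC)c1ccc(OCC(=O)C(C)(C)C)c(C)c1`: 130 nM
Compound 3 `CCn1c(C(=O)OC(C)CCO)ccc1C(CC)(CC)c1ccc(OCC(=O)C(C)(C)C)c(C)c1`: 380 nM

All three compounds share one core and were tested in an assay on HL-60 cells for agonist activity at vitamin D3 receptor (Homo sapiens), read by microscopy, with a stated time of 96 h; on this read-out lower numbers stand for an effect already at smaller amounts and higher numbers for an effect only at larger amounts of compound. Compound 3 gives the highest number of the three: a 4.9-fold higher number from compound 1 to compound 3 (0.69 log units; beyond the scatter) and a 2.9-fold higher number from compound 2 to compound 3 (0.47 log units; beyond the scatter), both modest steps, each beyond the scatter. The step of a 1.7-fold higher number from compound 1 to compound 2 (0.23 log units; within the scatter) lies within the scatter.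

Compound 4 `CCn1c(C(=O)OCc2ccc(F)cc2)ccc1C(CC)(CC)c1ccc(OCC(=O)C(C)(C)C)c(C)c1` has not yet been measured. It differs from compound 3 in this way: 4-fluorobenzyl in place of 3-hydroxy-1-methylpropyl on an oxygen next to a carbonyl group. Among the measured compounds shown here, no measured step changes the group on the ester oxygen; the two steps that touch this region of the molecule, a 4.9-fold higher number from compound 1 to compound 3 (0.69 log units; beyond the scatter) and a 2.9-fold higher number from compound 2 to compound 3 (0.47 log units; beyond the scatter), exchanged the group on the carbonyl carbon itself and moved the number by modest amounts. The change here is larger in kind than any measured one, and its direction cannot be read from the data. The step of a 1.1-fold higher number from compound 3 to compound 4 (0.02 log units; within the scatter) is therefore an expectation of roughly no change, with wide uncertainty. Compound 4 is estimated at 400 nM, in the range 100 nM to 1600 nM.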

Compound 4, half-maximal effective concentration: 9500 nM
Compound 4: the middle estimate sits 24-fold (1.38 log units) below what was measured, outside the stated range (above it).
By their numbers in this assay, from the lowest: compounds 1 and 2 (each within the scatter of the next); then compound 3; then compound 4.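

In this assay, the group on the oxygen next to the carbonyl group turns out to matter far more than the earlier exchanges suggested: replacing 3-hydroxy-1-methylpropyl with 4-fluorobenzyl gives a 25-fold higher number from compound 3 to compound 4 (1.40 log units; beyond the scatter) and is the largest step from any single change to compound 3. Measured against the two amides, the (4-fluorobenzyl)oxy group on the carbonyl carbon gives a 73-fold higher number from compound 2 to compound 4 (1.86 log units; beyond the scatter) and a 120-fold higher number from compound 1 to compound 4 (2.09 log units; beyond the scatter) as well, leaving compound 4 with the highest number of the four. Nothing measured here explains why this exchange raises the number so sharply.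

This single change removes a hydroxyl-bearing chain and brings in a fluorinated ring, so the compounds shown cannot tell which part is responsible. A plain benzyl ester, with no fluorine, and an unbranched 3-hydroxypropyl ester would help to separate these parts.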